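Anilide in place of propylamide: expected shift

The compounds below may be only part of what the source reports. "The series", "measured", "known", "first", "only" and "open" are said of these compounds alone.

Measured so far in a functional assay (brain) for inhibition, with Rattus norvegicus as the target; a higher number here means a weaker inhibitor, a lower number a stronger inhibitor
compound 1 `COc1cc2c(cc1O)CCC(C(=O)NCc1ccccc1)O2` gives 16600 nM
compound 2 `CCCNC(=O)C1CCc2cc(O)c(OC)cc2O1` gives 119000 nM

Of these two, compound 2 has the higher number and is the weaker inhibitor in this assay by a margin beyond the usual scatter. Still unmeasured is compound 3 `COc1cc2c(cc1O)CCC(C(=O)Nc1ccccc1)O2` which differs from compound 2 as follows: phenyl in place of propyl on an amide-type nitrogen that is, phenyl in place of propyl on an amide-type nitrogen.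

Among the compounds with values here, only one measured step bears on this change. It is a 7.2-fold higher number from compound 1 to compound 2 (0.86 log units; beyond the scatter) and it came with ethyl in place of phenyl on a saturated chain carbon bound to an amide-type nitrogen. That step is an indirect guide, since the phenyl of compound 3 sits on the amide-type nitrogen itself. A step somewhat smaller than that one is therefore expected, towards a lower number. The expected step is a 3.4-fold lower number from compound 2 to compound 3 (0.53 log units; beyond the scatter) and it rests on a single pair of compounds.

Compound 3 is estimated at 35000 nM with 10000 nM to 100000 nM as its expected range.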

Compound 3, half-maximal inhibitory concentration: 6900 nM
The estimate for compound 3 lay 5.1-fold (0.71 log units) above the measured number; measured number below the stated range.
By their numbers in this assay, from the lowest: compound 3; then compound 1; then compound 2.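

In this assay the amide-type nitrogen tolerates a ring placed directly on it, and the change from propylamino to anilino gives a large gain (a 17-fold lower number from compound 2 to compound 3 (1.24 log units; beyond the scatter)). The earlier pair left open whether the ring needed the benzyl carbon to lower the number, but phenyl in place of benzyl also goes down, if only modestly (a 2.4-fold lower number from compound 1 to compound 3 (0.38 log units; beyond the scatter)), so that carbon is not required and compound 3 is the strongest inhibitor of the three. No measurement is at hand that explains either step.

Going by these compounds, the order phenyl, benzyl, propyl rests on these three groups on a single core, so it remains open whether a chlorophenyl or methoxyphenyl on the same nitrogen would lower the number further, or whether a pyridyl ring would keep the gain seen with phenyl. A longer chain ending in a ring, such as phenethyl, and a cyclohexyl group in place of phenyl would show whether the gain follows the aromatic ring itself or simply the larger group on this nitrogen.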